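Swapping the chlorophenyl arm for a furan ring

The compounds below may be only part of what the source reports. "The series", "measured", "known", "first", "only" and "open" are said of these compounds alone.

Compound 1 `O=C(O)Cc1sc(C(c2ccc(F)cc2)c2ccc(F)cc2)nc1-c1ccc(Cl)cc1` was examined in an in vitro functional assay on HEK285-7 cells for antagonist activity at prostaglandin D2 receptor 2 (Homo sapiens), read by BRET and beta-arrestin recruitment (a higher number here means a larger maximal response, a lower number a smaller maximal response), where compound 1 reached 80%. Compound 2 `O=C(O)Cc1sc(C(c2ccccc2)c2ccc(F)cc2)nc1-c1ccc(Cl)cc1` gave 80%, so compound 1 stands level with compound 2, together the highest of the three numbers. Compound 3 `O=C(O)Cc1sc(NC(=O)c2ccccc2)nc1-c1ccc(Cl)cc1` gave 50%, a lower number than compound 1, beyond the scatter. For the measured compounds named here, the one step available, no change at the digits printed from compound 1 to compound 2 (within the scatter), concerns the fluoro on the diarylmethyl group, a place remote from the change that leads to compound 4.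

Compound 4 `O=C(O)Cc1sc(C(c2ccc(F)cc2)c2ccc(F)cc2)nc1-c1ccco1` differs from compound 1 in this way: furan-2-yl in place of 4-chlorophenyl on an aromatic carbon. Going by the values given here, no measured step touches this position, so the direction is open; the pair of compound 1 and compound 3 merely shows that a large change elsewhere on the shared core can lower the maximal response. Because no change at the digits printed from compound 1 to compound 2 (within the scatter) was flat, compound 1 is taken as the anchor and compound 4 is expected to give 72%, between 52% and 90%. This estimate amounts to a number 8 percentage points lower from compound 1 to compound 4 (within the scatter), a small downward lean rather than a confident prediction.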

Compound 4, largest response reached (reported as efficacy), in percent of the reference or control that the assay uses: 80%
For compound 4 the middle estimate is 8 percentage points below the measured one; the range from low to high includes it.
By their numbers in this assay, from the lowest: compound 3; then compounds 1, 2 and 4 (each within the scatter of the next).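

For the compounds shown here, at this position, the first reading in this assay is no change at the digits printed from compound 1 to compound 4 (within the scatter). On the aromatic carbon next to the ring nitrogen, the 4-chlorophenyl group, with its 7 heavy atoms and its chlorine, can thus give way to furan-2-yl, with 5 heavy atoms and 1 hydrogen-bond acceptor, and compound 4 still reaches 80%. Nothing measured on these compounds accounts for this result.

As far as these compounds go, whether a thiophene ring, a pyridine ring or an open chain such as a butyl group would fare the same at this place remains open. Also open, from the compounds shown here alone, is whether furan-2-yl would give the same result alongside the group that compound 3 carries in place of the diarylmethyl group.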